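A few compounds are considered here, and "the series" means these few. Any claim that something is new, unique, unknown or untested is made for them only; others in the source may bear on it.

In an ADME assay on L1210/0 cells (Mus musculus) for cytotoxicity, with a stated time of 48 h (a higher number here means a weaker inhibitor, a lower number a stronger inhibitor), compound 1 `[N-]=[N+]=NCc1cn([C@H]2C[C@H](O)[C@@H](CO)O2)c(=O)[nH]c1=O`, which carries azidomethyl on the shared core, gives 124000 nM. Compound 2 `CCCC#Cc1cn([C@H]2C[C@H](O)[C@@H](CO)O2)c(=O)[nH]c1=O` has pent-1-yn-1-yl in place of azidomethyl and gives > 200000 nM, which is a limit of the assay and not a number. The standing of compound 2 is therefore known only through (the limit of > 200000 nM in this assay, at which 1 of the 2 values shown sits).

Compound 3 `CCCc1cn([C@H]2C[C@H](O)[C@@H](CO)O2)c(=O)[nH]c1=O` changes the same group again: propyl in place of pent-1-yn-1-yl on an aromatic carbon. The new chain is shorter and has no triple bond, but it still has no hydrogen-bond donors or acceptors.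

Among the compounds with values here, only one measured step bears on this change: an at least 1.6-fold higher number from compound 1 to compound 2 (0.20 log units; that floor lies within the scatter). That step swapped one group for another in the same place and showed no change beyond the scatter, so no sizeable change is expected here in either direction in this assay. This is thin evidence, as it rests on a single step that ends in a limit. The expected step, an at least 1.1-fold lower number from compound 2 to compound 3 (0.07 log units; that floor lies within the scatter), is therefore an estimate that stays within the scatter. For compound 3 the estimated value is 170000 nM, with an expected range from 70000 nM to 400000 nM.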

Compound 3, half-maximal inhibitory concentration: > 200000 nM
Compound 3: no number, only a limit; the forecaster's own chance of this, stated with the estimate: 50%; middle value at least 1.1-fold (0.07 log units) from the limit.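

In this assay compound 3 joins compound 2 at the limit of the assay, and the step between these two compounds cannot be read, as both values are limits and not numbers: the limit of > 200000 nM in this assay, at which 2 of the 3 values shown sit. The readable comparison is an at least 1.6-fold higher number from compound 1 to compound 3 (0.20 log units; that floor lies within the scatter), and because this is only a floor within the scatter, it does not establish a real separation, although the true gap could be larger. What compound 3 adds is a second chain made only of carbon at this aromatic carbon, shorter than pent-1-yn-1-yl and without its triple bond, that also gives no number, whereas compound 1, with azidomethyl, gives 124000 nM.

As far as these compounds go, how far compound 2 and compound 3 lie beyond the limit stays open, so the effects of chain length and of the triple bond cannot be told apart. Also open, from the compounds shown here alone, is whether an amine, a carboxylic acid or a shorter chain such as methyl at this place would give a number in this assay.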